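A Methoxy Stand-in for Trifluoromethoxy on the Shared Core

The source may hold more compounds than are shown below. What is called first, only, known or untested is meant among the compounds shown, and "the series" means these compounds.

Compound 1 `Cc1ccc2nc(-c3cccc(OC(F)(F)F)c3)[nH]c(=O)c2c1` carries a trifluoromethoxy group on its pendant ring. In a functional assay on HCT-15 cells (Homo sapiens) for cytotoxicity, read by MTT assay, with a stated time of 2 days (a lower number here means a stronger inhibitor, a higher number a weaker inhibitor), compound 1 gives > 50000 nM, which is a limit of the assay and not a number, so its standing is the limit of > 50000 nM in this assay, at which 1 of the 3 values shown sits. Two companions frame the series: compound 2 `CCN(CC)c1ccc2nc(-c3ccccc3N(C)C)[nH]c(=O)c2c1` gives 4200 nM in this assay, and compound 3 `Cc1ccc2c(=O)[nH]c(-c3ccccc3OC(F)(F)F)nc2c1`, another trifluoromethoxy bearer, gives 15900 nM. Compound 4 `COc1cccc(-c2nc3ccc(C)cc3c(=O)[nH]2)c1` has not yet been measured; it differs from compound 1 by methyl in place of trifluoromethyl on an oxygen on an aromatic ring. For the measured compounds named here, no measured pair shows this change, and the limit on compound 1 leaves its direction open, so only a small shift in this assay is expected. Compound 4 is estimated at 35000 nM, spanning 8000 nM to 150000 nM. That expectation for compound 4 means an at least 1.4-fold lower number from compound 1 to compound 4 (0.15 log units; that floor lies within the scatter).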

Compound 4, half-maximal inhibitory concentration: 32000 nM
The estimate for compound 4 lay 1.1-fold (0.04 log units) above the measured number; measured number inside the range.
By their numbers in this assay, from the lowest: compound 2; then compounds 3 and 4 (each within the scatter of the next). At a limit, above all of these: compound 1.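

In this assay, methyl in place of trifluoromethyl on an oxygen on an aromatic ring gives an at least 1.5-fold lower number from compound 1 to compound 4 (0.19 log units; that floor lies within the scatter). For the compounds shown here, compound 4 thus supplies a number on this pendant ring, so the change has a direction for the first time, although its size is known only as a floor. Compound 1 remains a limit of the assay and not a number: the limit of > 50000 nM in this assay, at which 1 of the 4 values shown sits.

The compounds shown leave open how a hydroxyl or a longer chain such as ethoxy would read at this place in this assay. They also leave open whether the same change on compound 3 would give a step of similar size.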